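Replacing 1H-indol-4-yl with 3-(1-hydroxyethyl)phenyl on the shared core

The source may report more compounds than this note shows. Statements on the series, on what has been measured and on what is new or still open speak of the compounds shown alone.

Within the data shown here, in a physicochemical assay for lipophilicity, at pH 7.4 (a higher number here means a more lipophilic compound, a lower number a more polar compound), two compounds with the shared core have numbers so far. Compound 1 (`CNC(=O)c1cc(C(=O)NC2CC2)cn(CC2CCCCC2)c1=O`) gives 4 there, while compound 2 (`CNC(=O)c1cc(C(=O)NC2CC2)cn(Cc2cccc3[nH]ccc23)c1=O`) gives 2.9 and so holds the lower of the two numbers.

Compound 3 (`CNC(=O)c1cc(C(=O)NC2CC2)cn(Cc2cccc([C@@H](C)O)c2)c1=O`), still unmeasured, comes from compound 2 by a single change (3-(1-hydroxyethyl)phenyl in place of 1H-indol-4-yl on a saturated chain carbon bound to an aromatic nitrogen). The group that enters carries a hydrogen-bond acceptor, and the group that leaves carries none.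

Among the measured compounds shown here, one measured step touches this same place (a number 1.10 log units lower from compound 1 to compound 2 (beyond the scatter)), and it shows that a swap here can move the number a long way. That step swapped different groups, so it gives a sense of scale but no direct guide to direction. For the measured compounds named here, no measured step tests the acceptor, which makes the direction a judgement. A moderate fall in this assay is expected, beyond the scatter but smaller than the measured step. The estimated change is a number 0.70 log units lower from compound 2 to compound 3 (beyond the scatter). The estimated value for compound 3 is 2.2 within an expected range from 1.7 to 2.7 until a measurement arrives.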

Compound 3, distribution coefficient: 2.2
The estimate for compound 3 equals the measured number at the digits printed; low and high end bracket the measured number.
By their numbers in this assay, from the lowest: compound 3; then compound 2; then compound 1.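

Swapping 1H-indol-4-yl for 3-(1-hydroxyethyl)phenyl gives, in this assay, a number 0.70 log units lower from compound 2 to compound 3 (beyond the scatter), and the two groups have the same number of heavy atoms, so this number can move at this place with no change in that count. The change also brings oxygen where the leaving group has nitrogen, removes the five-membered aromatic ring, adds a hydrogen-bond acceptor and introduces a defined stereocentre. The wider comparison, a number 1.80 log units lower from compound 1 to compound 3 (beyond the scatter), extends the range seen on this saturated chain carbon bound to an aromatic nitrogen, with the three groups now ordered from cyclohexyl at the top, through 1H-indol-4-yl, to 3-(1-hydroxyethyl)phenyl at the bottom.

No supporting measurement accounts for these shifts, so their cause remains unknown.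

With several features changing together, the compounds shown leave open which of them accounts for the step from the indole to the hydroxyethyl-bearing ring. A plain phenyl group would show what the ring contributes without the 1-hydroxyethyl group, and an amine in place of the hydroxyl would test whether the result depends on that oxygen.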